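Swapping a Nitrophenyl for a Bromophenyl on the Core

The compounds below may be only part of what the source reports. "The series", "measured", "known", "first", "only" and "open" are said of these compounds alone.

Compound 2 `CC(=O)N1N=C(c2cccc3ccccc23)CC1c1ccccc1[N+](=O)[O-]` was tested in a functional assay on PC-3 cells (Homo sapiens) for cytotoxicity, read by sulforhodamine B assay, with a stated time of 48 h (on this read-out lower numbers stand for stronger inhibition and higher numbers for weaker inhibition), where compound 2 gives 3540 nM. Compound 1 `COc1cc(C2CC(c3ccc(Br)cc3)=NN2C(C)=O)cc(OC)c1OC` gives 3450 nM in this assay, and the two values lie within the usual scatter of each other, so they are read as the same. Compound 3 `CC(=O)N1N=C(c2cccc3ccccc23)CC1c1cccc(Br)c1` has not yet been measured. It differs from compound 2 by 3-bromophenyl in place of 2-nitrophenyl on a saturated ring carbon. Among the measured compounds shown here, no measured pair shows the effect of this change, so only a cautious expectation is possible. Compound 3 is expected to give 3500 nM in this assay, with a range from 1200 nM to 10000 nM. That estimate means a step of a 1.0-fold lower number from compound 2 to compound 3 (0.00 log units; within the scatter), expected to stay within the scatter.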

Compound 3, half-maximal inhibitory concentration: 12000 nM
Compound 3: middle estimate off by 3.4-fold (0.54 log units), on the low side, outside the stated range (above it).
By their numbers in this assay, from the lowest: compounds 1 and 2 (each within the scatter of the next); then compound 3.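

In this assay, putting 3-bromophenyl in place of 2-nitrophenyl on the saturated ring carbon brings a 3.4-fold higher number from compound 2 to compound 3 (0.53 log units; beyond the scatter) and thus weaker inhibition. Compounds 1 and 2 could not show this, as they differ in more than one place. This pair shows that the group at this position can change the read-out, although the step is modest.

Going by these compounds, it remains open whether the bromine itself or its place on the phenyl ring matters, and how an amine or a carboxylic acid on that ring would read. No measurement shown here explains the step.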